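Ethoxy in place of bromo: working notes on compound 4

The source may report more compounds than this note shows. Statements on the series, on what has been measured and on what is new or still open speak of the compounds shown alone.

In an ADME assay on CCRF-CEM cells (Homo sapiens) for antiproliferative activity, with a stated time of 48 h (a lower number here means a stronger inhibitor, a higher number a weaker inhibitor), three compounds sharing one core have been measured. Compound 1 `C=C(Br)C(=O)Nc1ccc(/C=C/C(=O)c2ccc(Cl)c(Cl)c2)cc1` gives 1700 nM, compound 2 `C=C(Br)C(=O)Nc1ccc(/C=C/C(=O)c2ccc(Br)cc2)cc1` gives 990 nM and compound 3 `C=C(Br)C(=O)Nc1ccc(/C=C/C(=O)c2cccc(OC)c2)cc1` gives 2300 nM. Compound 2 holds the lowest of the three numbers, but it is not separated from compound 1, as a 1.7-fold lower number from compound 1 to compound 2 (0.23 log units; within the scatter) shows. The third step, a 1.4-fold higher number from compound 1 to compound 3 (0.13 log units; within the scatter), also stays inside the scatter.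

Compound 4 `C=C(Br)C(=O)Nc1ccc(/C=C/C(=O)c2ccc(OCC)cc2)cc1` follows from compound 2 by one change: ethoxy in place of bromo on an aromatic carbon, para to a large group. For the measured compounds named here, no measured compound carries ethoxy. Going by the values given here, the nearest precedent is compound 3, which has a 3-methoxyphenyl group, so both the group and its place differ from compound 4. That comparison gave a modest step, a 2.3-fold higher number from compound 2 to compound 3 (0.37 log units; beyond the scatter). A move of similar size in the same direction is therefore expected, with a 1.7-fold higher number from compound 2 to compound 4 (0.23 log units; within the scatter) as the estimated step in this assay. For compound 4 the estimated value is 1700 nM, with an expected range of 750 nM to 3800 nM.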

Compound 4, half-maximal inhibitory concentration: 750 nM
Compound 4: middle estimate off by 2.3-fold (0.36 log units), on the high side; the measured number falls inside the stated range.
By their numbers in this assay, from the lowest: compounds 4, 2, 1 and 3 (each within the scatter of the next, the first and the last beyond it).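

In this assay, ethoxy in place of bromo on an aromatic carbon, para to a large group, gives a 1.3-fold lower number from compound 2 to compound 4 (0.12 log units; within the scatter), so compound 4 is not separated from compound 2. For the compounds shown here, this is the first reading of an oxygen-linked group at this place, and it shows that the change from 1 heavy atom to 3 heavy atoms, with 1 hydrogen-bond acceptor entering, leaves the number within the scatter. No measurement is available that explains this result.

The compounds shown do not tell whether the number would also hold with a longer chain such as butoxy, or with an amine or a carboxylic acid at this place. They also leave open whether methoxy at this same place would match ethoxy, which would separate the effect of the group from that of its place.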